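Nitrophenyl in Place of Fluorophenyl: An Expected Antiproliferative Value

This account rests on a few compounds, and the source may have more. Where it says the series, first, only, none or still open, it means among the compounds named here.

Compound 1 `COc1ccc(C(=O)/C=C/c2cccc(F)c2)c2c1C=CC(C)(C)O2` was examined in a functional assay on HT-29 cells (Homo sapiens) for antiproliferative activity, read by MTT assay, with a stated time of 24 h; a higher number here means a weaker inhibitor, a lower number a stronger inhibitor. In this assay compound 1 gives only a limit, > 10000 nM, and not a number. Of the two values recorded so far, one sits at that limit (the limit of > 10000 nM in this assay, at which 1 of the 2 values shown sits). Compound 2 `COc1ccc(C(=O)/C=C/c2ccc3ccccc3c2)c2c1C=CC(C)(C)O2`, which carries a different aryl group on the shared core, gives 4480 nM in this assay. Compound 3 `COc1ccc(C(=O)/C=C/c2ccc([N+](=O)[O-])cc2)c2c1C=CC(C)(C)O2` has not yet been measured. It differs from compound 1 in one place: 4-nitrophenyl in place of 3-fluorophenyl on a double-bonded chain carbon bound to a double-bonded chain carbon. Going by the values given here, no measured pair shows how such a change moves the read-out, and the starting point is itself a limit, so no direction can be read from the data. The step of an at least 1.2-fold lower number from compound 1 to compound 3 (0.09 log units; that floor lies within the scatter) is expected to be small, perhaps modestly toward a stronger inhibitor. Compound 3 is accordingly expected to give about 8000 nM, with a range from 2000 nM to 30000 nM.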

Compound 3, half-maximal inhibitory concentration: 3730 nM
The estimate for compound 3 lay 2.1-fold (0.33 log units) above the measured number; low and high end bracket the measured number.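

Exchanging 3-fluorophenyl for 4-nitrophenyl on a double-bonded chain carbon bound to a double-bonded chain carbon gives, in this assay, an at least 2.6-fold lower number from compound 1 to compound 3 (0.42 log units; beyond the scatter). Going by these compounds alone, this is the first pair in which a single change at this position can be read, and it shows that the aryl group carried there can move the read-out toward a stronger inhibitor. The full size of the step cannot be told, because compound 1 gives only a limit and not a number: the limit of > 10000 nM in this assay, at which 1 of the 3 values shown sits.

The compounds shown leave open whether the step belongs to the nitro group or to where it stands on the ring, which a 4-fluorophenyl or a 3-nitrophenyl group at this position would separate. From the compounds shown here alone, how a 4-aminophenyl or a 4-carboxyphenyl group would read there is equally open.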